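Swapping a dichlorobenzyl arm for carbamoylmethyl

The source may hold more compounds than are shown below. What is called first, only, known or untested is meant among the compounds shown, and "the series" means these compounds.

Measured compounds:
- compound 1, `Nc1nc(O)c2c(n1)n(C1OC(CO)[C@@H](O)[C@H]1O)c(=O)n2Cc1ccc(Cl)c(Cl)c1`: 15%
- compound 2, `C=CCn1c(=O)n(C2C[C@H](O)C(CO)O2)c2nc(N)nc(O)c21`: 75%
- compound 3, `C=CCn1c(=S)n(C2OC(CO)[C@@H](O)C(O)[C@H]2O)c2nc(N)nc(O)c21`: 3%

These three share a core and were tested in a functional assay on YAC-1 cells (Mus musculus); a lower number here means a smaller maximal response, a higher number a larger maximal response. Compound 1 stands second highest of the three numbers; compound 3 sits nearest, lower by a gap beyond the scatter, and compound 2 sits furthest, far higher. Compound 4, `NC(=O)Cn1c(=O)n(C2OC(CO)[C@@H](O)[C@H]2O)c2nc(N)nc(O)c21`, is not yet measured. It differs from compound 1 in one place: carbamoyl in place of 3,4-dichlorophenyl on a saturated chain carbon bound to an aromatic nitrogen. Within the data shown here, no step between measured compounds isolates this change, so the direction rests on loose footing. The expectation for compound 4 is a rise beyond the scatter, a number 20 percentage points higher from compound 1 to compound 4 (beyond the scatter), with wide uncertainty. Compound 4 is estimated at 35%, within 5% to 75%.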

Compound 4, largest response reached (reported as maximal response), in percent of the reference or control that the assay uses: 42%
Beside the measured number, compound 4's estimate is 7 percentage points below it; low and high end bracket the measured number.
By their numbers in this assay, from the lowest: compound 3; then compound 1; then compound 4; then compound 2.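

Swapping the 3,4-dichlorobenzyl arm for carbamoylmethyl gives the first comparison here that differs in one place, and in this assay it reads a number 27 percentage points higher from compound 1 to compound 4 (beyond the scatter) with the rest of the shared core unchanged. The response therefore depends on what sits at this place, and the 3,4-dichlorophenyl ring is not required for a response. No measurement shown explains why the number moves. Still open, on these data alone, is how a carboxylic acid or an amine would read in place of the carbamoyl, and whether a plain benzyl without chlorine would read closer to compound 1 or compound 4.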